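Second methyl group on the chloro compound: working notes

The source may hold more compounds than are shown below. What is called first, only, known or untested is meant among the compounds shown, and "the series" means these compounds.

Compound 1 `Cc1cc2nc(-c3cn(-c4ccccc4)nc3-c3ccccc3)[nH]c2cc1C` gives 14500 nM here
Compound 2 `Cc1cc2nc(-c3cn(-c4ccccc4)nc3-c3ccc(F)cc3)[nH]c2cc1C` gives > 50000 nM as a limit, not a number
Compound 3 `Cc1ccc2[nH]c(-c3cn(-c4ccccc4)nc3-c3ccc(Cl)cc3)nc2c1` gives 4640 nM here

All three readings come from a functional assay on A549 cells (Homo sapiens) for antiproliferative activity, read by MTT assay, with a stated time of 48 h (on this read-out higher numbers stand for weaker inhibition and lower numbers for stronger inhibition), as the common test. Compound 3 has the lowest of the two numeric values (4640 nM), and the nearest neighbour with a higher number is compound 1 (14500 nM).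

Compound 4 `Cc1cc2nc(-c3cn(-c4ccccc4)nc3-c3ccc(Cl)cc3)[nH]c2cc1C` differs from compound 3 in one place by methyl in place of hydrogen on an aromatic carbon as methyl in place of hydrogen on an aromatic carbon, ortho to a methyl group. Within the data shown here, no measured step covers this change directly. Among the measured compounds shown here, the only measured step is an at least 3.4-fold higher number from compound 1 to compound 2 (0.53 log units; beyond the scatter) and it concerns fluoro in place of hydrogen on an aromatic carbon, so it bears on this change only loosely. It does show that compounds with both methyl groups can move well beyond the scatter.

A small move toward a higher number is expected in this assay, probably not beyond the scatter, given that compound 1 with both methyl groups reads 14500 nM in this test. The expected step is a 1.7-fold higher number from compound 3 to compound 4 (0.24 log units; within the scatter) on this limited evidence. For compound 4 the estimated value is 8000 nM with 2500 nM to 26000 nM as the expected range.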

Compound 4, half-maximal inhibitory concentration: 17700 nM
For compound 4 the middle estimate is 2.2-fold (0.34 log units) below the measured one, and the stated range covers the measured number.
By their numbers in this assay, from the lowest: compound 3; then compounds 1 and 4 (each within the scatter of the next). At a limit, above all of these: compound 2.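

In this assay, methyl in place of hydrogen on an aromatic carbon, ortho to a methyl group, gives a 3.8-fold higher number from compound 3 to compound 4 (0.58 log units; beyond the scatter), which shows that this position on the chloro compound does not tolerate the change without a measurable loss. With both methyl groups present, chloro in place of hydrogen gives a 1.2-fold higher number from compound 1 to compound 4 (0.09 log units; within the scatter), so compound 1 and compound 4 cannot be told apart, and the chloro group shows no separate benefit on this background. Chloro in place of fluoro gives an at least 2.8-fold lower number from compound 2 to compound 4 (0.45 log units; beyond the scatter), but compound 2 is a limit and not a number, so this step sets only a bound: the limit of > 50000 nM in this assay, at which 1 of the 4 values shown sits.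

The comparison of one methyl group with two rests on the chloro pair alone, which leaves open whether the same step appears with the unsubstituted phenyl or the fluoro compound. On these data alone, it also remains open how this position responds to a group other than methyl, such as a methoxy group, an amine or a carboxylic acid, and whether any of these would read closer to compound 3 or to compound 4.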